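Removing the bromine from a triazole-linked lignan lactone

The source may report more compounds than this note shows. Statements on the series, on what has been measured and on what is new or still open speak of the compounds shown alone.

Compound 1 `COC(=O)[C@@H](NC(=O)CCC(=O)Oc1ccc(C[C@H]2C(=O)OC[C@@H]2Cc2ccc(OC)c(OC)c2)cc1OC)c1c[nH]c2ccccc12` reaches only a limit in an ADME assay on HeLa cells (Homo sapiens) for cytotoxicity, read by MTT assay; on this read-out lower numbers stand for stronger inhibition and higher numbers for weaker inhibition: compound 1 gives >= 600000 nM, which is a limit of the assay and not a number. Within the data shown here, compound 2 `COc1ccc(C[C@H]2COC(=O)[C@@H]2Cc2ccc(OCc3cn(-c4ccc(Br)cc4)nn3)c(OC)c2)cc1OC` is the one compound with a number in this assay, where compound 2 gives 128000 nM. Compound 3 `COc1ccc(C[C@H]2COC(=O)[C@@H]2Cc2ccc(OCc3cn(-c4ccccc4)nn3)c(OC)c2)cc1OC` differs from compound 2 by hydrogen in place of bromo on an aromatic carbon. Among the measured compounds shown here, no measured step of this kind is available, so the step from compound 2 to compound 3 is expected to stay within the usual scatter, with no clear direction, a 1.2-fold higher number from compound 2 to compound 3 (0.07 log units; within the scatter). Compound 3 is therefore estimated at 150000 nM, ranging from 60000 nM to 400000 nM.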

Compound 3, half-maximal inhibitory concentration: 124000 nM
Beside the measured number, compound 3's estimate is 1.2-fold (0.08 log units) above it, within the range that was stated.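

In this assay, among these compounds, replacing 4-bromophenyl with phenyl gives a 1.0-fold lower number from compound 2 to compound 3 (0.01 log units; within the scatter), so this is the first step that can be read for this position. With hydrogen in place of bromo on this aromatic carbon, the two compounds stand within the scatter of each other. Compound 2 and compound 3 both give numbers instead of a limit, so the comparison can be made: the limit of >= 600000 nM in this assay, at which 1 of the 3 values shown sits.

Bromo and hydrogen alone leave open whether another group at this place, such as an amine or a carboxylic acid, would move the number beyond the scatter.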